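From dichlorophenyl to hydroxyphenyl on a shared core

This account rests on a few compounds, and the source may have more. Where it says the series, first, only, none or still open, it means among the compounds named here.

In a functional assay on A549 cells (Homo sapiens) for cytotoxicity, read by MTT assay, with a stated time of 72 h (on this read-out lower numbers stand for stronger inhibition and higher numbers for weaker inhibition), compound 1 (`O=C(N/N=C/c1ccc(F)cc1Cl)Nc1cc2c(Nc3ccc(F)c(Cl)c3)ncnc2cc1O[C@H]1CCOC1`) gives 27200 nM and compound 2 (`O=C(N/N=C/c1cccc(Cl)c1Cl)Nc1cc2c(Nc3ccc(F)c(Cl)c3)ncnc2cc1O[C@H]1CCOC1`) gives 25000 nM on the same core. These two values sit level (a 1.1-fold lower number from compound 1 to compound 2 (0.04 log units; within the scatter)), so compound 2 shares the high end of the numbers. Compound 3 (`O=C(N/N=C/c1ccc(O)cc1O)Nc1cc2c(Nc3ccc(F)c(Cl)c3)ncnc2cc1O[C@H]1CCOC1`), which carries a dihydroxyphenyl group on that carbon, gives 9360 nM as the lowest number of the three (a 2.9-fold lower number from compound 1 to compound 3 (0.46 log units; beyond the scatter); a 2.7-fold lower number from compound 2 to compound 3 (0.43 log units; beyond the scatter)).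

Compound 4 (`O=C(N/N=C/c1ccc(O)cc1)Nc1cc2c(Nc3ccc(F)c(Cl)c3)ncnc2cc1O[C@H]1CCOC1`) has not yet been measured. It differs from compound 2 at one place (4-hydroxyphenyl in place of 2,3-dichlorophenyl on a carbon with a double bond to nitrogen), where 4-hydroxyphenyl replaces 2,3-dichlorophenyl on a carbon with a double bond to nitrogen. Among the measured compounds shown here, the nearest guide is compound 3, the only measured compound with hydroxyl groups on this ring, and its step (a 2.7-fold lower number from compound 2 to compound 3 (0.43 log units; beyond the scatter)) was modest. Swapping one chlorinated ring for another showed no change beyond the scatter (a 1.1-fold lower number from compound 1 to compound 2 (0.04 log units; within the scatter)). A similar modest fall is therefore expected (a 2.1-fold lower number from compound 2 to compound 4 (0.32 log units; beyond the scatter)). The estimated value for compound 4 is 12000 nM and the expected range runs from 6000 nM up to 25000 nM.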

Compound 4, half-maximal inhibitory concentration: 1320 nM
For compound 4 the middle estimate is 9.1-fold (0.96 log units) above the measured one; measured number below the stated range.
By their numbers in this assay, from the lowest: compound 4; then compound 3; then compounds 2 and 1 (each within the scatter of the next).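

In this assay, among the compounds shown here, this position on the carbon with a double bond to nitrogen proves far more sensitive than the earlier compounds suggested: 4-hydroxyphenyl brings large falls from both chlorinated rings (a 19-fold lower number from compound 2 to compound 4 (1.28 log units; beyond the scatter); a 21-fold lower number from compound 1 to compound 4 (1.31 log units; beyond the scatter)). Having a hydroxy group on the ring is not the whole story, since compound 3 already has one, and hydrogen in place of its other hydroxy group still lowers the number (a 7.1-fold lower number from compound 3 to compound 4 (0.85 log units; beyond the scatter)). No measurement here explains why these changes have such different sizes.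

The compounds shown do not separate the loss of chlorine from the gain of hydroxy. No plain phenyl ring appears among them. A 4-methoxyphenyl or 4-aminophenyl group would test whether the hydroxy group itself is needed.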